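Notes on the step from compound 2 to compound 3

A few compounds are considered here, and "the series" means these few. Any claim that something is new, unique, unknown or untested is made for them only; others in the source may bear on it.

- compound 1 `Cc1ccccc1NC(=O)CN1CCN(c2nnc(Cc3ccccc3)c3ccccc23)CC1` gives "not active" (no number reported) (no number reported)
- compound 2 `O=C(CN1CCN(c2nnc(Cc3ccncc3)c3ccccc23)CC1)Nc1cc(C(F)(F)F)ccc1Cl` gives 1850 nM (the only number so far)

For the measured compounds named here, in a functional assay on A549 cells (Homo sapiens) for cytotoxicity, read by MTT assay, with a stated time of 72 h (a higher number here means a weaker inhibitor, a lower number a stronger inhibitor), compound 2 (1850 nM) holds the only number, and compound 1 has none. Going by the values given here, no ranking by size is therefore possible, and no step between measured compounds can be read.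

Compound 3 `Cc1ccccc1NC(=O)CN1CCN(c2nnc(Cc3ccncc3)c3ccccc23)CC1` has 2-methylphenyl in place of 2-chloro-5-(trifluoromethyl)phenyl on an amide-type nitrogen. The same 2-methylphenyl stands on the amide-type nitrogen of compound 1 ("not active" (no number reported)), and this is the only pointer available. On that basis a weaker result is expected in this assay, and a report without a number would be no surprise. The expected change is a loss beyond the usual scatter (a 4.3-fold higher number from compound 2 to compound 3 (0.64 log units; beyond the scatter)), although a single compound supports this expectation only thinly. For compound 3 the estimated value is (8000 nM), with an expected range of (2500 nM to 30000 nM).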

Compound 3, half-maximal inhibitory concentration: 43100 nM
The estimate for compound 3 lay 5.4-fold (0.73 log units) below the measured number; the whole stated range lies below it.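

In this assay, replacing 2-chloro-5-(trifluoromethyl)phenyl with 2-methylphenyl on the amide-type nitrogen gives a 23-fold higher number from compound 2 to compound 3 (1.37 log units; beyond the scatter) and provides the first readable measure of how much the group at this position can matter in the series. For the compounds shown here, with the same 2-methylphenyl group, compound 3 gives 43100 nM and so still has a number, whereas compound 1 has none, and no step to compound 1 can be read. Nothing measured among the compounds shown accounts for the size of this step.

The step exchanges the chlorine, the trifluoromethyl and the methyl in a single change, leaving open whether the difference follows one of these groups or only their combination. A phenyl group carrying chlorine alone, one carrying trifluoromethyl alone, or one carrying a methoxy group or an amine would help separate these contributions at the same amide-type nitrogen, while the shared core stays unchanged.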